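From Phenyl to 4-Nitrophenyl: One More Group

This account rests on a few compounds, and the source may have more. Where it says the series, first, only, none or still open, it means among the compounds named here.

Within the data shown here, in a functional assay on MDA-MB-231 cells (Homo sapiens) for inhibition, read by MTT assay, with a stated time of 48 h (a higher number here means a weaker inhibitor, a lower number a stronger inhibitor), compound 2 `COc1cc(-c2nccn3cc(-c4ccccc4)nc23)cc(OC)c1OC` gives 364 nM, the lower of the two numbers so far, while compound 1 `COc1cc(-c2nccn3cc(-c4ccc(Cl)cc4)nc23)cc(OC)c1OC` gives 2090 nM. Compound 3 `COc1cc(-c2nccn3cc(-c4ccc([N+](=O)[O-])cc4)nc23)cc(OC)c1OC` has nitro in place of hydrogen on an aromatic carbon, para to a large group: nitro in place of hydrogen on an aromatic carbon. Among the measured compounds shown here, only one measured step bears on this: a 5.7-fold lower number from compound 1 to compound 2 (0.76 log units; beyond the scatter), with hydrogen in place of chloro. Adding nitro is therefore expected to raise the number, although a single step is thin evidence. The expected change is a 3.3-fold higher number from compound 2 to compound 3 (0.52 log units; beyond the scatter) in this assay. For compound 3 the estimated value is 1200 nM, with a range of 350 nM to 4000 nM.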

Compound 3, half-maximal inhibitory concentration: > 10000 nM
Compound 3 was reported as a limit; the forecaster's own chance of this, stated with the estimate: 3%; middle value at least 8.3-fold (0.92 log units) away from the limit.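

The reading for compound 3 is a limit: the limit of > 10000 nM in this assay, at which 1 of the 3 values shown sits. Even so, nitro at this position gives an at least 27-fold higher number from compound 2 to compound 3 (1.43 log units; beyond the scatter), and replacing chloro with nitro there gives an at least 4.7-fold higher number from compound 1 to compound 3 (0.67 log units; beyond the scatter), so the two groups are not interchangeable at this position. In this assay, neither group improves on hydrogen, and the plain phenyl of compound 2 keeps the lowest number of the three compounds.

As far as these compounds go, whether an amine or a methyl group at the same position would also raise the number remains open. So does whether any group there can bring the number below that of compound 2.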